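Cyclopropyl to isopropyl on the aromatic carbon

A few compounds are considered here, and "the series" means these few. Any claim that something is new, unique, unknown or untested is made for them only; others in the source may bear on it.

Going by the values given here, compound 3 `CN(C)C(=O)c1cccnc1NCCCN1CCN(c2ccccc2C2CC2)CC1` gives 0.631 nM in a functional assay for antagonist activity at Alpha-1A adrenergic receptor (Oryctolagus cuniculus) (on this read-out higher numbers stand for weaker binding and lower numbers for tighter binding), the highest of the three numbers so far; compound 2 `CN(C)C(=O)c1cccnc1NCCCN1CCN(c2ccccc2OCC2CC2)CC1` gives 0.159 nM and compound 1 `CN(C)C(=O)c1cccnc1NCCCN1CCN(c2ccccc2OCC(F)(F)F)CC1` gives 0.1 nM, the steps being a 4.0-fold higher number from compound 2 to compound 3 (0.60 log units; beyond the scatter) and a 6.3-fold higher number from compound 1 to compound 3 (0.80 log units; beyond the scatter). Compound 4 `CC(C)c1ccccc1N1CCN(CCCNc2ncccc2C(=O)N(C)C)CC1` differs from compound 3 by isopropyl in place of cyclopropyl on an aromatic carbon. Among the compounds with values here, no measured step exchanges one three-carbon group for another on the aromatic carbon; the nearest analogue is a 1.6-fold higher number from compound 1 to compound 2 (0.20 log units; within the scatter), an exchange of small groups on a saturated chain carbon bound to an oxygen. The 2,2,2-trifluoroethoxy and cyclopropylmethoxy changes of compounds 1 and 2 do not bear on this one. For compound 4 the expected step is a 1.0-fold lower number from compound 3 to compound 4 (0.00 log units; within the scatter), none beyond the scatter. Compound 4 is therefore estimated at 0.63 nM in this assay, between 0.3 nM and 1.5 nM.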

Compound 4, dissociation constant: 0.398 nM
Compound 4: the middle estimate sits 1.6-fold (0.20 log units) above what was measured; measured number inside the range.
By their numbers in this assay, from the lowest: compounds 1 and 2 (each within the scatter of the next); then compounds 4 and 3 (each within the scatter of the next).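

In this assay, isopropyl in place of cyclopropyl on the aromatic carbon gives a 1.6-fold lower number from compound 3 to compound 4 (0.20 log units; within the scatter), so on this read-out the ring of the cyclopropyl group is not needed at this position. Compound 4 still stands apart from the two ether-linked compounds, with a 2.5-fold higher number from compound 2 to compound 4 (0.40 log units; beyond the scatter) and a 4.0-fold higher number from compound 1 to compound 4 (0.60 log units; beyond the scatter), so the open-chain group does not close either gap. Nothing measured here explains these steps.

Open, on these data alone, is whether isopropoxy on this aromatic carbon would reach the numbers of compounds 1 and 2. Also open, as far as these compounds go, is how an amine at this carbon would read in this assay.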